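The source may hold more compounds than are shown below. What is called first, only, known or untested is meant among the compounds shown, and "the series" means these compounds.

Measured in an ADME assay on MDBK cells (Bos taurus) for cytotoxicity, read by MTT assay, with a stated time of 96 h; on this read-out lower numbers stand for higher toxicity in this test and higher numbers for lower toxicity in this test:
Compound 1 `Cn1c(-c2ccc([N+](=O)[O-])cc2)nc2cc(C(F)(F)F)ccc21` gives > 100000 nM in this assay; this value is a limit of the assay.
Compound 2 `Cn1c(-c2ccc(N)cc2)nc2cc(C(F)(F)F)ccc21` gives 74000 nM in this assay.
Compound 3 `COc1ccc(-c2nc3cc(Cl)c(Cl)cc3[nH]2)c([N+](=O)[O-])c1` gives 28000 nM in this assay.

Compound 1 and compound 2 share one core and differ only by amino in place of nitro on an aromatic carbon. That change gave an at least 1.3-fold lower number from compound 1 to compound 2 (0.13 log units; that floor lies within the scatter); the size of this step is open because of the limit of > 100000 nM in this assay, at which 1 of the 3 values shown sits. Compound 3 stands lowest of the two numbers in this assay; its nearest neighbour is compound 2, and that gap lies beyond the scatter. The difference between the core of compound 3 and the core of compound 1 is not broken down here.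

Compound 4 `COc1ccc(-c2nc3cc(Cl)c(Cl)cc3[nH]2)c(N)c1` is not yet measured. It differs from compound 3 by amino in place of nitro on an aromatic carbon. This is the same kind of change as from compound 1 to compound 2, but not the same: in compound 2 the amino stands para to a large group, whereas in compound 4 it stands ortho to a large group and meta to a methoxy group. Within the data shown here, the only measured example of this kind of change is the step from compound 1 to compound 2, and that step rests on a limit.

Among the measured compounds shown here, for compound 4 a step of about a 1.4-fold lower number from compound 3 to compound 4 (0.15 log units; within the scatter) is expected in this assay, set beside the earlier step, because an at least 1.3-fold lower number from compound 1 to compound 2 (0.13 log units; that floor lies within the scatter) is the single measured instance of this kind of change. Compound 4 is therefore estimated at 20000 nM in this assay, with an expected range from 8000 nM to 50000 nM.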

Compound 4, half-maximal cytotoxic concentration: 6500 nM
Compound 4: the middle estimate sits 3.1-fold (0.49 log units) above what was measured; measured number below the stated range.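

In this assay, amino in place of nitro on an aromatic carbon gives a 4.3-fold lower number from compound 3 to compound 4 (0.63 log units; beyond the scatter), a step that can be read in full on the core of compound 3 and that lies beyond the usual scatter. Both pairs point the same way as printed, which is as far as the transfer from one core to the other can be taken, and whether the size of the step carries over remains unsettled: the same change on two cores in this assay, an at least 1.3-fold lower number (0.13 log units; that floor lies within the scatter) from compound 1 to compound 2 and a 4.3-fold lower number (0.63 log units; beyond the scatter) from compound 3 to compound 4; the limit leaves it open whether they differ

Among these compounds, compound 1 gives > 100000 nM in this assay, which is a limit of the assay and not a number, so the series offers only one fully measured instance of this change and no general rule for other cores.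

Still open, from the compounds shown here alone, is whether the lower number goes with the amino itself or would also appear with another group on the same aromatic carbon, such as a methylamino group or an acetamide. Also open is which part of the core sets the size of the step, the methoxy group or the chlorine atoms, as the compounds shown do not separate the two.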